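This account rests on a few compounds, and the source may have more. Where it says the series, first, only, none or still open, it means among the compounds named here.

Measured compounds:
- compound 1, `OC[C@H]1O[C@@H](n2cc(Br)c3c(NO)ncnc32)[C@H](O)[C@@H]1O`: > 100000 nM
- compound 2, `Nc1ncnc2c1ccn2COC(CO)CO`: > 100000 nM
- compound 3, `CCNc1ncnc2c1c(Cl)cn2COC(CO)CO`: > 100000 nM

In an ADME assay on HFF cells (Homo sapiens) for cytotoxicity (a lower number here means a stronger inhibitor, a higher number a weaker inhibitor), compound 2 gives > 100000 nM, which is a limit of the assay rather than a number. Compound 1 likewise sits at a limit, and so does compound 3; the limit of > 100000 nM in this assay, at which 3 of the 3 values shown sit, describes where all three stand. Compound 4, `OCC(CO)OCn1ccc2c(NO)ncnc21`, has not yet been measured. It differs from compound 2 by hydroxy in place of hydrogen on a nitrogen on an aromatic ring. Going by the values given here, no step between two measured compounds is available to guide this change, and no further information is known about it. Since every value shown is a limit, a step in this assay from compound 2 to compound 4 is expected to be none beyond the scatter: compound 4 is expected to give 150000 nM, within 50000 nM to 500000 nM, most likely again reported only as a limit.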

Compound 4, half-maximal inhibitory concentration: > 100000 nM
Compound 4: a limit, no number; the forecaster's own chance of this, stated with the estimate: 85%; the middle value lies beyond the limit too.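

Compound 4 gives > 100000 nM, which is a limit of the assay, so no step from compound 2 can be read, because both compounds stand at the same kind of limit: the limit of > 100000 nM in this assay, at which 4 of the 4 values shown sit.

What the compounds shown leave open is how much the change from amino to hydroxyamino alters the result in this assay.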